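Swapping Chloro for Bromo on a Cinnamoyl Sulfonamide

The compounds below may be only part of what the source reports. "The series", "measured", "known", "first", "only" and "open" are said of these compounds alone.

Of the compounds shown here, two have so far been tested in a functional assay on B16-F10 cells (Mus musculus) for antiproliferative activity, read by ELISA and MTT assay, with a stated time of 48 h; a lower number here means a stronger inhibitor, a higher number a weaker inhibitor. Compound 1 `O=C(/C=C/c1ccc(F)cc1)NS(=O)(=O)c1ccc(Br)cc1` carries a fluoro group on one ring and a bromo group on the other; in this assay compound 1 gives 2.8 ug/mL. Compound 2 `O=C(/C=C/c1ccc([N+](=O)[O-])cc1)NS(=O)(=O)c1ccc(Cl)cc1` carries a nitro group on one ring and a chloro group on the other; in this assay compound 2 gives 13.7 ug/mL. Of these two numbers compound 2 has the higher one, so it is the weaker inhibitor, and the gap to compound 1 lies beyond the usual scatter. Compound 1 and compound 2 differ in two places at once, so the numbers alone cannot say which change carries that gap.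

Compound 3 `O=C(/C=C/c1ccc([N+](=O)[O-])cc1)NS(=O)(=O)c1ccc(Br)cc1` keeps the nitro group of compound 2 and changes only the other ring: bromo in place of chloro on an aromatic carbon. The new group sits on an aromatic carbon of a six-membered aromatic ring of carbon only, para to a large group. Within the data shown here, no measured pair shows this change on its own, and one heavy atom is exchanged for one heavy atom. The expected step of a 1.4-fold lower number from compound 2 to compound 3 (0.14 log units; within the scatter) is small and within the scatter. Compound 3 is expected to give 10 ug/mL, between 4 ug/mL and 25 ug/mL.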

Compound 3, half-maximal inhibitory concentration: 13.9 ug/mL
Compound 3: the middle estimate sits 1.4-fold (0.14 log units) below what was measured; low and high end bracket the measured number.
By their numbers in this assay, from the lowest: compound 1; then compounds 2 and 3 (each within the scatter of the next).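

In this assay, with the nitro group held fixed, bromo and chloro on an aromatic carbon para to a large group cannot be told apart: the data give a 1.0-fold higher number from compound 2 to compound 3 (0.01 log units; within the scatter). The earlier gap spanned two places at once, but it can now be read one place at a time: with bromo held fixed, nitro in place of fluoro on an aromatic carbon gives a 5.0-fold higher number from compound 1 to compound 3 (0.70 log units; beyond the scatter), a step of about the same size as that earlier gap, so among these three compounds the difference in activity goes with the fluoro-to-nitro change and not with the halogen swap. Nothing measured here explains why either step has the size it does.

Among these compounds, the match between bromo and chloro has been seen only with nitro on the other ring, so it remains open whether the two would also match with fluoro there. Fluoro and nitro are the only groups shown on that ring, and a methoxy group or an amine in the same place could show whether the activity seen with fluoro can be matched or exceeded.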